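A carbamoyl swap on the core of compound 2

The source may hold more compounds than are shown below. What is called first, only, known or untested is meant among the compounds shown, and "the series" means these compounds.

Compound 1 `NC(=O)N/N=C/c1ccc(OCc2ccc3no[n+]([O-])c3c2)cc1` gives > 200 uM (a limit of the assay)
Compound 2 `CC1(C)[N+]([O-])=c2ccc(COc3ccccc3/C=N\NC(=N)N)cc2=[N+]1[O-]` gives 114 uM (a number)

Within the data shown here, in an ADME assay on cells (Erythrocyte, Homo sapiens), read by spectrophotometry and hemolysis, with a stated time of 24 h (on this read-out lower numbers stand for stronger inhibition and higher numbers for weaker inhibition), compound 2 gives 114 uM as the only actual number so far. Among the measured compounds shown here, compound 1, the only other compound measured, stands at a limit in this assay at > 200 uM and nothing finer is known for it.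

Compound 3 `CC1(C)[N+]([O-])=c2ccc(COc3ccccc3/C=N\NC(N)=O)cc2=[N+]1[O-]` has not yet been measured. It differs from compound 2 in a single place: a group of 3 heavy atoms (1 carbon, 1 nitrogen, 1 oxygen; no ring) in place of a group of 3 heavy atoms (1 carbon, 2 nitrogen; no ring), on an amine nitrogen. A carbamoyl thus enters on an amine nitrogen, where a group of the same heavy-atom count but no common name leaves.

For the measured compounds named here, no measured step shows what this change does in this assay, so the expectation is a cautious one. It rests on the value of compound 2 at 114 uM. It also rests on compound 1 at > 200 uM, which is a limit of the assay. The expected change, a 2.1-fold higher number from compound 2 to compound 3 (0.32 log units; beyond the scatter), runs toward weaker inhibition and is estimated to lie only slightly beyond the scatter, and the assay may well report just a limit. For compound 3 the estimate is 240 uM, with an expected range from 110 uM to 500 uM in this measurement.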

Compound 3, concentration for 50% inhibition: 50 uM
For compound 3 the middle estimate is 4.8-fold (0.68 log units) above the measured one; measured number below the stated range.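

In this assay, putting a carbamoyl in place of the group with no common name, on an amine nitrogen whose other neighbours are a double-bonded nitrogen, gives a 2.3-fold lower number from compound 2 to compound 3 (0.36 log units; beyond the scatter), a modest move toward stronger inhibition that lies beyond the usual scatter. Among these compounds, as the only measured step at this position, it shows that the number responds to this change on the core of compound 2, and that compound 3 carries the carbamoyl there while still giving an actual number rather than a limit. Compound 1 remains the one compound known only through a limit of the assay, so it adds no number to set beside this step: the limit of > 200 uM in this assay, at which 1 of the 3 values shown sits.

The compounds shown leave open whether an acetyl group, a thiocarbamoyl group or a simple methyl group on the same amine nitrogen would move the number in the same direction, and how far. They also leave open whether this step would carry over to the core of compound 1, and they offer no measurement that explains why the carbamoyl gives the lower number.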